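A few compounds are considered here, and "the series" means these few. Any claim that something is new, unique, unknown or untested is made for them only; others in the source may bear on it.

Values so far in a physicochemical assay for solubility, read by HPLC, using the shake flask method, in phosphate buffer, measured as kinetic solubility, with a stated time of 20 h, at pH 6.5; on this read-out higher numbers stand for higher solubility and lower numbers for lower solubility:

- compound 1 `C[C@@H]1CN(C(=O)c2ccnc(Nc3nc4cnc(Nc5ccc(F)c(C(F)(F)F)c5)cc4[nH]3)c2)C[C@H](C)N1` gives 200000 nM
- compound 2 `C[C@@H]1CN(C(=O)c2ccnc(Nc3nc4cnc(Nc5cccc(C(F)(F)F)c5)cc4[nH]3)c2)C[C@H](C)N1` gives 200000 nM
- compound 3 `C[C@@H]1CN(C(=O)c2ccnc(Nc3nc4cnc(Nc5ccc(F)c(F)c5)cc4[nH]3)c2)C[C@H](C)N1` gives 100000 nM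

Compound 3, at 100000 nM, cannot be told apart from the other two on these numbers. The measured steps are a 2.0-fold lower number from compound 1 to compound 3 (0.30 log units; within the scatter) and a 2.0-fold lower number from compound 2 to compound 3 (0.30 log units; within the scatter), and the remaining step is no change at the digits printed from compound 1 to compound 2 (within the scatter). All three lie within the scatter.

Compound 4 `O=C(c1ccnc(Nc2nc3cnc(Nc4ccc(F)c(F)c4)cc3[nH]2)c1)N1CCC(F)(F)CC1` keeps the 3,4-difluorophenyl group of compound 3 and the shared core. The structural change is 4,4-difluoropiperidin-1-yl in place of 3,5-dimethylpiperazin-1-yl on a carbonyl carbon and sits on a carbonyl carbon. Among the measured compounds shown here, none of the measured steps touches that group. For the measured compounds named here, they alter only the fluoro and trifluoromethyl substitution, so they give no measured size for this exchange, and no measured compound carries anything other than 3,5-dimethylpiperazin-1-yl on the carbonyl.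

The expectation therefore starts from compound 3 at 100000 nM and rests on the structural change alone, so its range is held wide. The expected change is a 33-fold lower number from compound 3 to compound 4 (1.52 log units; beyond the scatter), a step beyond the scatter towards a lower number in this assay. For compound 4 the estimated value is 3000 nM, with an expected range from 300 nM to 30000 nM.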

Compound 4, solubility: < 5000 nM
Compound 4: only a limit was reported (the forecaster's own chance of this, stated with the estimate: 15%); the middle value does not contradict the limit.
By their numbers in this assay, from the lowest: compounds 3, 1 and 2 (each within the scatter of the next). At a limit, below all of these: compound 4.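

In this assay, among the compounds shown here, 4,4-difluoropiperidin-1-yl in place of 3,5-dimethylpiperazin-1-yl on a carbonyl carbon gives an at least 20-fold lower number from compound 3 to compound 4 (1.30 log units; beyond the scatter), so the group on the carbonyl is the first place where a single exchange moves the read-out beyond the scatter. The earlier steps shown here, which alter only the fluoro and trifluoromethyl substitution among compounds 1, 2 and 3, all stayed within the scatter, and they gave no sign of what the carbonyl position could do. Compound 4 is reported only as a limit and not as a number: the limit of < 5000 nM in this assay, at which 1 of the 4 values shown sits.

This one exchange swaps a group with 1 hydrogen-bond donor, 1 hydrogen-bond acceptor and 2 defined stereocentres for one with 0 hydrogen-bond donors, 0 hydrogen-bond acceptors and 2 fluorine atoms, and the compounds shown do not separate these differences from one another. An unsubstituted piperazine, a morpholine or a piperidine without fluorine on the carbonyl would divide the step into parts, and 4,4-difluoropiperidin-1-yl paired with the 3-(trifluoromethyl)phenyl group of compound 2 would test whether the step carries over to another aromatic substituent.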